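Moving the Methyl on the Alkynyl Phenyl Ring

The source may hold more compounds than are shown below. What is called first, only, known or untested is meant among the compounds shown, and "the series" means these compounds.

For the measured compounds named here, compound 2 `CCOC(=O)c1nc2ccccc2nc1C#Cc1ccccc1C` gives 31600 nM in a functional assay on U-87MG ATCC cells (Homo sapiens) for antiproliferative activity, read by MTT assay, with a stated time of 72 h (on this read-out lower numbers stand for stronger inhibition and higher numbers for weaker inhibition), the highest of the two numbers measured so far; its nearest neighbour, compound 1 `CCOC(=O)c1nc2ccccc2nc1C#Cc1ccccc1`, gives 3300 nM in this assay. Going by the values given here, the only measured step, a 9.6-fold higher number from compound 1 to compound 2 (0.98 log units; beyond the scatter), is the one that separates these two compounds. Compound 3 `CCOC(=O)c1nc2ccccc2nc1C#Cc1cccc(C)c1` differs from compound 2 in a single place: 3-methylphenyl in place of 2-methylphenyl on a triple-bonded carbon. No atom is added or removed; the same methyl simply sits elsewhere on the same ring. Among the compounds with values here, the step from compound 1 to compound 2 is the only measured step that bears on this change, and it shows that a 2-methylphenyl in place of a plain phenyl raises the number markedly. Whether a 3-methylphenyl does the same is not told by any measured pair. Because a 9.6-fold higher number from compound 1 to compound 2 (0.98 log units; beyond the scatter) was clearly beyond the scatter, compound 3 is expected to land between the two measured compounds, with a move of a 4.0-fold lower number from compound 2 to compound 3 (0.60 log units; beyond the scatter). Compound 3 is therefore estimated at 8000 nM, within a range of 2500 nM to 25000 nM.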

Compound 3, half-maximal inhibitory concentration: 5500 nM
Compound 3: the middle estimate sits 1.5-fold (0.16 log units) above what was measured; the range from low to high includes it.
By their numbers in this assay, from the lowest: compounds 1 and 3 (each within the scatter of the next); then compound 2.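

In this assay, moving the methyl alone is enough to change the read-out: with the same atoms in both compounds, the swap of 2-methylphenyl for 3-methylphenyl on the triple-bonded carbon gives a 5.7-fold lower number from compound 2 to compound 3 (0.76 log units; beyond the scatter), a step beyond the scatter. The earlier step could have been read as a cost of any methyl on this ring, but the new result ties it to the 2-methylphenyl alone, at least among these two placements. The 3-methylphenyl, by contrast, cannot be told apart from the plain phenyl, since a 1.7-fold higher number from compound 1 to compound 3 (0.22 log units; within the scatter) lies within the scatter. Nothing measured here gives a reason why the two methylphenyl groups differ.

Still open, going by these compounds, is whether the tolerance of the 3-methylphenyl extends to anything other than a methyl, such as an ethyl group, a longer chain, an amine or a carboxylic acid on the same ring. Also open, on these data alone, is whether any group on this ring could bring the number clearly under that of the plain phenyl of compound 1, as neither methyl does so here.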